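The source may report more compounds than this note shows. Statements on the series, on what has been measured and on what is new or still open speak of the compounds shown alone.

Working notes on the series.

Compound 1, `Cc1c2c(n3c1CCNC[C@@H](C)[C@H](C)Nc1cc-3ccc1C(N)=O)CC(C)(C)CC2=O`, is the reference point. In a functional assay on NCI-H1975 cells (Homo sapiens) for antiproliferative activity (a lower number here means a stronger inhibitor, a higher number a weaker inhibitor), compound 1 gives 27 nM, the lowest of the two numbers in hand. Compound 2, `Cc1c2c(n3c1CCN(C(=O)CN)C[C@@H](C)[C@H](C)Nc1cc-3ccc1C(N)=O)CC(C)(C)CC2=O`, carries an (aminomethyl)carbonyl group in place of hydrogen on the amine nitrogen in the ring; in this assay compound 2 gives 190 nM, which is a 7.0-fold higher number from compound 1 to compound 2 (0.85 log units; beyond the scatter).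

Compound 3, `Cc1c2c(n3c1CCN(C(=O)[C@@H](O)C(C)C)C[C@@H](C)[C@H](C)Nc1cc-3ccc1C(N)=O)CC(C)(C)CC2=O`, has not yet been measured in this assay. Its difference from compound 1 is (1-hydroxy-2-methylpropyl)carbonyl in place of hydrogen on an amine nitrogen in a ring. Going by the values given here, the only measured step that bears on this change is the acylation of the same ring nitrogen, a 7.0-fold higher number from compound 1 to compound 2 (0.85 log units; beyond the scatter), which moved the number beyond the scatter and in the weakening direction. Among the compounds with values here, compound 3 carries a different acyl group at that nitrogen, the (1-hydroxy-2-methylpropyl)carbonyl group, and no measured pair separates the effect of one acyl group from another. Within the data shown here, with only that one step to go on, a weakening of modest size, a 4.8-fold higher number from compound 1 to compound 3 (0.68 log units; beyond the scatter), is expected for compound 3. The estimate for compound 3 in this assay is 130 nM, with a range from 50 nM to 350 nM.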

Compound 3, half-maximal inhibitory concentration: 31 nM
For compound 3 the middle estimate is 4.2-fold (0.62 log units) above the measured one, outside the stated range (below it).
By their numbers in this assay, from the lowest: compounds 1 and 3 (each within the scatter of the next); then compound 2.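

Acylation of the ring amine nitrogen carries no cost of its own in this assay, as the (1-hydroxy-2-methylpropyl)carbonyl group gives a 1.1-fold higher number from compound 1 to compound 3 (0.06 log units; within the scatter) and so leaves the number where it stood without the acyl group. What sits on the carbonyl carbon decides the outcome for the two acyl groups in hand: 1-hydroxy-2-methylpropyl in place of aminomethyl gives a 6.1-fold lower number from compound 2 to compound 3 (0.79 log units; beyond the scatter) and shows that the weakening seen with compound 2 belongs to that particular acyl group, not to acylation as such. No measurement on hand offers a reason for the difference between these two acyl groups.

From the compounds shown here alone, it remains open whether the hydroxyl or the branched carbon chain of the 1-hydroxy-2-methylpropyl group separates compound 3 from compound 2, and a plain acetyl group, a 2-methylpropanoyl group without the hydroxyl, or the opposite configuration at the defined stereocentre would help to settle this. Also open, going by these compounds, is whether this nitrogen tolerates substituents other than acyl groups, such as a sulfonyl or a simple alkyl group, or an acyl group ending in a carboxylic acid.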